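Ret series: outer aryl ring nitrogens and a new side chain

The source may report more compounds than this note shows. Statements on the series, on what has been measured and on what is new or still open speak of the compounds shown alone.

Measured compounds in an assay on isolated protein for inhibition of proto-oncogene tyrosine-protein kinase receptor Ret (Homo sapiens); on this read-out lower numbers stand for stronger inhibition and higher numbers for weaker inhibition:
Compound 1 `COCc1cccc2[nH]c(-c3n[nH]c4ncc(-c5cccnc5)cc34)nc12`; in this assay compound 1 gives 1100 nM.
Compound 2 `COCc1cccc2[nH]c(-c3n[nH]c4ncc(-c5ccncc5)cc34)nc12`; in this assay compound 2 reaches only the limit > 100000 nM.
Compound 3 `COCc1cccc2[nH]c(-c3n[nH]c4ncc(-c5cncnc5)cc34)nc12`; in this assay compound 3 reaches only the limit > 100000 nM.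

Among the measured compounds shown here, compound 1 holds the only real number in this assay; the two other values are limits and not numbers. Both measured steps away from compound 1 change the nitrogen pattern of the outer six-membered ring: an at least 90-fold higher number from compound 1 to compound 2 (1.95 log units; beyond the scatter) and an at least 90-fold higher number from compound 1 to compound 3 (1.95 log units; beyond the scatter). In each case the number rises to the limit of > 100000 nM in this assay, at which 2 of the 3 values shown sit. The step that the two limits leave unreadable from compound 2 to compound 3 cannot be read because both of its ends sit at the limit of > 100000 nM in this assay, at which 2 of the 3 values shown sit.

Compound 4 `CCCNCc1cncc(-c2cnc3[nH]nc(-c4nc5c(COC)cccc5[nH]4)c3c2)c1` keeps the pyridin-3-yl of compound 1 and differs from it by (propylamino)methyl in place of hydrogen on an aromatic carbon. For the measured compounds named here, no measured step touches a substituent on that ring; the steps seen concern only ring nitrogens, so none of them bears directly on this change. With no guide from the series, the expectation for compound 4 in this assay is a step of uncertain size, a 2.2-fold lower number from compound 1 to compound 4 (0.34 log units; beyond the scatter), with a wide range either way. Compound 4 is estimated at 500 nM, between 80 nM and 3500 nM.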

Compound 4, half-maximal inhibitory concentration: > 10000 nM
Compound 4: only a limit was reported (the forecaster's own chance of this, stated with the estimate: 5%); middle value at least 20-fold (1.30 log units) from the limit.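

In this assay, the (propylamino)methyl on the pyridin-3-yl ring, two atoms from the ring nitrogen, gives an at least 9.0-fold higher number from compound 1 to compound 4 (0.95 log units; beyond the scatter). Among the compounds shown here, the earlier compounds showed only what happens when the nitrogens of the outer ring change, whereas this is the first result for a substituent added to that ring, and with the pyridin-3-yl kept, the number still rises. The value of compound 4 is a limit of the assay and not a number, so this step has a floor but no known top: the limit of > 10000 nM in this assay, at which 1 of the 4 values shown sits.

Open, as far as these compounds go, is whether the rise belongs to the secondary amine or to the chain as such: a butyl chain or a methoxyethyl group at the same carbon would separate the two, and a small aminomethyl or a plain methyl would show whether any group is accepted there. Also open, from the compounds shown here alone, is whether the same (propylamino)methyl behaves differently on another carbon of the pyridin-3-yl ring, and whether a tertiary amine such as a dimethylaminomethyl or a morpholine-bearing methyl group follows compound 4.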